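From Hydroxymethylphenyl to Carbamoylphenyl: One Swap, One Estimate

The source may report more compounds than this note shows. Statements on the series, on what has been measured and on what is new or still open speak of the compounds shown alone.

Measured in a functional assay on HCT-116 cells (Homo sapiens) for inhibition, read by sulforhodamine B assay, with a stated time of 48 h; on this read-out higher numbers stand for weaker inhibition and lower numbers for stronger inhibition:
- Compound 1 `COc1cc2c(cc1CC1OC1(C)C)C(=O)C[C@@H](c1ccc(O)cc1)O2`: 29000 nM
- Compound 2 `COc1ccc([C@@H]2C/C(=N/OCc3cn(-c4ccccc4CO)nn3)c3cc(CC=C(C)C)c(OC)cc3O2)cc1`: 29900 nM

In this assay compound 2, at 29900 nM, lies within the usual scatter of compound 1, so the two values cannot be told apart. The next molecule is compound 3 `COc1ccc([C@@H]2C/C(=N/OCc3cn(-c4ccc(C(N)=O)cc4)nn3)c3cc(CC=C(C)C)c(OC)cc3O2)cc1`, not yet measured. It carries 4-carbamoylphenyl in place of 2-(hydroxymethyl)phenyl on an aromatic nitrogen. The rest of the molecule stays as in compound 2. Within the data shown here, no measured pair here shows what a swap of this kind does, so no large move in either direction is expected. Among the measured compounds shown here, the only close guide is compound 2 at 29900 nM. The estimated 1.2-fold lower number from compound 2 to compound 3 (0.08 log units; within the scatter) stays within the scatter. For compound 3 the expected value is 25000 nM, with an estimated range of 9000 nM to 60000 nM.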

Compound 3, half-maximal inhibitory concentration: 7130 nM
For compound 3 the middle estimate is 3.5-fold (0.54 log units) above the measured one, and the stated range ends above it.
By their numbers in this assay, from the lowest: compound 3; then compounds 1 and 2 (each within the scatter of the next).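

In this assay, putting 4-carbamoylphenyl in place of 2-(hydroxymethyl)phenyl on the aromatic nitrogen gives a 4.2-fold lower number from compound 2 to compound 3 (0.62 log units; beyond the scatter) and is the only listed step so far. The group on this nitrogen therefore matters to the read-out, even with the rest of the molecule unchanged. The two groups share one six-membered aromatic ring of carbon only and match in their counts of hydrogen-bond donors and acceptors, so those counts alone do not separate them, and nothing measured here explains the step.

The names of the two groups show that both the substituent and its position on the phenyl ring differ, and 2-carbamoylphenyl or 4-(hydroxymethyl)phenyl would be needed to tell those two changes apart. From the compounds shown here alone, what a 4-carboxyphenyl or 4-aminophenyl group would do at this same place also remains open.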